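This account rests on a few compounds, and the source may have more. Where it says the series, first, only, none or still open, it means among the compounds named here.

Working notes on the series. The shared core of compound 1 `Cc1nc(SCC(=O)Nc2nc(-c3ccc(Cl)cc3)cs2)n(Nc2ccccc2)c1C` carries an anilino group and a 4-chlorophenyl group, and in a functional assay on SF-295 cells (Homo sapiens) for antiproliferative activity, read by sulforhodamine B assay, with a stated time of 48 h (on this read-out higher numbers stand for weaker inhibition of growth and lower numbers for stronger inhibition of growth), compound 1 gives 2290 nM, the highest of the two numbers recorded so far. Among the measured compounds shown here, compound 2 `Cc1ccc(Nn2c(SCC(=O)Nc3nc(-c4ccccc4)cs3)nc(C)c2C)cc1` differs from compound 1 in two places, so no single step links them; in this assay compound 2 gives 1060 nM, a number that stands apart from compound 1 beyond the scatter.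

Compound 3 `COc1ccc(Nn2c(SCC(=O)Nc3nc(-c4ccc(Cl)cc4)cs3)nc(C)c2C)cc1` is the next member to be measured in this assay. Its change from compound 1 is methoxy in place of hydrogen on an aromatic carbon. For the measured compounds named here, no measured step of this kind exists in the set, so the size and direction are uncertain; a step within or just beyond the scatter is expected, in the direction of a lower number, since compound 2 with its own substituted anilino ring gives 1060 nM. Compound 3 is estimated at 1500 nM in this assay, within 600 nM to 4500 nM, an expected step of a 1.5-fold lower number from compound 1 to compound 3 (0.18 log units; within the scatter).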

Compound 3, concentration for 50% growth inhibition: 2180 nM
Compound 3: middle estimate off by 1.5-fold (0.16 log units), on the low side; the measured number falls inside the stated range.
By their numbers in this assay, from the lowest: compound 2; then compounds 3 and 1 (each within the scatter of the next).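

In this assay, among the compounds shown here, the change from anilino to (4-methoxyphenyl)amino gives the first single-place comparison: a 1.1-fold lower number from compound 1 to compound 3 (0.02 log units; within the scatter). With the 4-chlorophenyl group and the rest of the core held fixed, methoxy in place of hydrogen at this place, para to a large group, gives no change that this read-out can separate from the scatter. Nothing available on these compounds offers an explanation for this result.

As far as these compounds go, it remains open whether a different group at this same place, such as an amine, a carboxylic acid or a longer alkoxy chain, would give a step beyond the scatter. From the compounds shown here alone, it is also open whether the methoxy step keeps its size with plain phenyl in place of the 4-chlorophenyl group, as this reading rests on a single pair.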